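The source may hold more compounds than are shown below. What is called first, only, known or untested is meant among the compounds shown, and "the series" means these compounds.

Working notes on the series. In an assay on isolated protein for inhibition of protein kinase C epsilon type (Homo sapiens), read by coupled enzyme assay (a lower number here means a stronger inhibitor, a higher number a weaker inhibitor), compound 1 `N#CC1(c2cc(CCO)cc(-c3ccnc4[nH]nc(C(F)(F)F)c34)c2)CC1` gives 25 nM, compound 2 `C[C@H](O)Cc1cc(-c2ccnc3[nH]nc(C(F)(F)F)c23)cc(C2(C#N)CC2)c1` gives 51 nM, and compound 3 `N#CC1(c2cc(CC(O)C(F)(F)F)cc(-c3ccnc4[nH]nc(C(F)(F)F)c34)c2)CC1` gives 267 nM. Compound 2 stands second highest of the three numbers, a 2.0-fold higher number from compound 1 to compound 2 (0.31 log units; beyond the scatter) and a 5.2-fold higher number from compound 2 to compound 3 (0.72 log units; beyond the scatter). Compound 4 `COCCc1cc(-c2ccnc3[nH]nc(C(F)(F)F)c23)cc(C2(C#N)CC2)c1` differs from compound 2 by methoxymethyl in place of 1-hydroxyethyl on a saturated chain carbon bound to an aromatic carbon. Among the measured compounds shown here, no measured step touches the hydroxyl itself: a 2.0-fold higher number from compound 1 to compound 2 (0.31 log units; beyond the scatter) and an 11-fold higher number from compound 1 to compound 3 (1.03 log units; beyond the scatter) alter the carbon bearing it and leave the donor in place, so they bear on the change only loosely. With the donor removed and the chain rearranged while the atom count is unchanged, a modest step in this assay is expected for compound 4, most likely toward a higher number, estimated at 70 nM (25 nM to 200 nM), a step of a 1.4-fold higher number from compound 2 to compound 4 (0.14 log units; within the scatter).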

Compound 4, inhibition constant: 145 nM
The estimate for compound 4 lay 2.1-fold (0.32 log units) below the measured number; the range from low to high includes it.
By their numbers in this assay, from the lowest: compound 1; then compound 2; then compounds 4 and 3 (each within the scatter of the next).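

In this assay, among the compounds shown here, this is the first step at this place that removes the hydroxyl hydrogen rather than altering the carbon bearing the hydroxyl: a 5.8-fold higher number from compound 1 to compound 4 (0.76 log units; beyond the scatter), and the isomeric change gives a 2.8-fold higher number from compound 2 to compound 4 (0.45 log units; beyond the scatter). Against the 2,2,2-trifluoro-1-hydroxyethyl group, methoxymethyl shows a 1.8-fold lower number from compound 3 to compound 4 (0.27 log units; within the scatter), so these two groups cannot be told apart at this place. Nothing available accounts for these steps.

Going by these compounds, whether an amine at the chain end would keep the number of compound 1 stays open. So does whether an ethyl ether would follow the methyl ether of compound 4.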